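Removing One Methoxy from the Carbonyl-Side Ring

The source may hold more compounds than are shown below. What is called first, only, known or untested is meant among the compounds shown, and "the series" means these compounds.

Of the compounds shown here, three sharing one core have been measured in a functional assay on NCI-H522 cells (Homo sapiens) for inhibition, read by sulforhodamine B assay, with a stated time of 48 h; a higher number here means a weaker inhibitor of growth, a lower number a stronger inhibitor of growth. Compound 1 `COc1cc(-c2cc(/C=C/C(=O)c3ccc(N)cc3)[nH]n2)cc(OC)c1OC` gives 1620 nM, compound 2 `COc1cc(-c2cc(/C=C/C(=O)c3ccc(Cl)c(Cl)c3)[nH]n2)cc(OC)c1OC` gives 1330 nM, and compound 3 `COc1ccc(C(=O)/C=C/c2cc(-c3cc(OC)c(OC)c(OC)c3)n[nH]2)cc1OC` gives 180 nM, the lowest of the three numbers: a 9.0-fold lower number from compound 1 to compound 3 (0.95 log units; beyond the scatter) and a 7.4-fold lower number from compound 2 to compound 3 (0.87 log units; beyond the scatter), both beyond the scatter, while a 1.2-fold lower number from compound 1 to compound 2 (0.09 log units; within the scatter) stays within it. Compound 4 `COc1ccc(C(=O)/C=C/c2cc(-c3cc(OC)c(OC)c(OC)c3)n[nH]2)cc1` has not yet been measured. It differs from compound 3 by hydrogen in place of methoxy on an aromatic carbon; cut one bond further out, the same difference reads 3,4-dimethoxyphenyl to 4-methoxyphenyl. Each measured step swaps the whole group on the carbonyl carbon, so none of them tests the loss of a single methoxy; they show only that what sits on that carbon moves the number modestly. A smaller move than those steps is therefore expected, most likely toward a higher number, and the step is expected to be a 2.2-fold higher number from compound 3 to compound 4 (0.35 log units; beyond the scatter). Compound 4 is estimated at 400 nM, within a range from 150 nM to 1200 nM.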

Compound 4, concentration for 50% growth inhibition: 1470 nM
Compound 4: middle estimate off by 3.7-fold (0.57 log units), on the low side; the measured number lies above the stated range.
By their numbers in this assay, from the lowest: compound 3; then compounds 2, 4 and 1 (each within the scatter of the next).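

In this assay, removing a single methoxy gives an 8.2-fold higher number from compound 3 to compound 4 (0.91 log units; beyond the scatter), beyond the scatter, so this one group matters far more than its two heavy atoms might suggest, something the earlier swaps of the whole group could not show. Among these compounds, with hydrogen in its place, the number no longer stands apart from those of the other two groups: a 1.1-fold higher number from compound 2 to compound 4 (0.04 log units; within the scatter) and a 1.1-fold lower number from compound 1 to compound 4 (0.04 log units; within the scatter) both lie within the scatter, leaving 3,4-dimethoxyphenyl as the only group of the four with a clearly lower number. Nothing available here explains why this methoxy counts for so much.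

As far as these compounds go, whether a methoxy is specifically required at this position remains open, since a hydroxyl or an ethoxy there could tell whether its oxygen alone suffices or a larger chain also fits. Also open, from the compounds shown here alone, is how much the other methoxy on this ring contributes.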